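The source may report more compounds than this note shows. Statements on the series, on what has been measured and on what is new or still open speak of the compounds shown alone.

Measured compounds:
compound 1, `COc1ccccc1NC(=S)N/N=C/c1ccc2ccccc2n1`, 91700 nM
compound 2, `CN(C)C(=S)N/N=C/c1cc2cccnc2s1`, > 100000 nM

Among the compounds with values here, in a functional assay on HL-60 cells (Homo sapiens) for antiproliferative activity, read by sulforhodamine B assay, with a stated time of 72 h (a lower number here means a stronger inhibitor, a higher number a weaker inhibitor), compound 1 gives 91700 nM, the only value that is an actual number. Compound 2 returns only a limit of the assay, > 100000 nM, so no number is known for it; one of the two values shown therefore sits at the limit (the limit of > 100000 nM in this assay, at which 1 of the 2 values shown sits). Compound 1 thus stands as the sole measured point with a real reading, and that reading is a weak one.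

Compound 3, `COc1ccc(C)cc1NC(=S)N/N=C/c1ccc2ccccc2n1`, keeps the core of compound 1 and differs from it in one place: methyl in place of hydrogen on an aromatic carbon, a methyl in place of hydrogen on an aromatic carbon. No measured step with a change of this kind is shown, so the direction of the step cannot be read off from the data. A single methyl added to a weak inhibitor is expected to move the value little, most likely within the usual scatter, and the estimated step from compound 1 to compound 3 is a 1.2-fold lower number from compound 1 to compound 3 (0.09 log units; within the scatter). Compound 3 is therefore estimated at 75000 nM in this assay, with a likely range from 30000 nM to 180000 nM.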

Compound 3, half-maximal inhibitory concentration: > 100000 nM
Compound 3: a limit, no number (the forecaster's own chance of this, stated with the estimate: 35%); at least 1.3-fold (0.12 log units) between middle value and limit.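

In this assay, a methyl in place of hydrogen on an aromatic carbon, para to a methoxy group and meta to a large group, gives an at least 1.0-fold higher number from compound 1 to compound 3 (0.03 log units; that floor lies within the scatter). Within the data shown here, compound 3 returns only a limit of the assay, > 100000 nM, so this step is a floor and not a measured size, and it gives no sign that a methyl at this position brings a gain in strength, which the earlier compounds could not show because none of them carried a change at this position. The true size of the step stays unknown, and the series now rests mostly on readings that carry no number: the limit of > 100000 nM in this assay, at which 2 of the 3 values shown sit.

What the compounds shown leave open is whether another group on this aromatic carbon, such as an amine, a carboxylic acid or a longer chain, would give a real reading in this assay. Among these compounds, also open is what would follow from replacing the methoxy group of compound 1 with a hydroxyl or a chlorine atom, since the one measured number here offers no steps from which to judge that group.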